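This account rests on a few compounds, and the source may have more. Where it says the series, first, only, none or still open, it means among the compounds named here.

Compound 1 `COc1ccc(-c2cc(C(=O)/C=C/c3ccccc3)nc3cc(-c4ccccc4)nn23)cc1OC`, compound 2 `COc1ccc(-c2cc(C(=O)/C=C/c3ccc(C)cc3)nc3cc(-c4ccccc4)nn23)cc1OC` and compound 3 `COc1cc(-c2cc(/C=C/C(=O)c3ccc(C)cc3)nc3cc(-c4ccccc4)nn23)cc(OC)c1OC` share a core, while compound 4 `COc1cc(-c2cc(/C=C/C(=O)c3ccccc3)nc3cc(-c4ccccc4)nn23)cc(OC)c1OC` has not yet been tested. In an ADME assay on HEK293 cells (Homo sapiens) for antiproliferative activity, read by MTT assay, with a stated time of 24 h (on this read-out lower numbers stand for stronger inhibition and higher numbers for weaker inhibition), compound 1 gives 64100 nM, compound 2 gives 57400 nM and compound 3 gives 50400 nM; these three numbers sit within the scatter of one another, so none of them can be ranked against the others. The change from compound 2 to compound 1 is hydrogen in place of methyl on an aromatic carbon, and it made a 1.1-fold higher number from compound 2 to compound 1 (0.05 log units; within the scatter). The difference between the cores of compound 2 and compound 3 is not broken down here. Compound 4 is related to compound 3 by hydrogen in place of methyl on an aromatic carbon, the same change as from compound 2 to compound 1, since both changes sit at a place described in the same words. Because a 1.1-fold higher number from compound 2 to compound 1 (0.05 log units; within the scatter) lay within the scatter, the step of a 1.1-fold higher number from compound 3 to compound 4 (0.04 log units; within the scatter) is expected to be of similar size. In this assay compound 4 is therefore estimated at 55000 nM, with a range from 30000 nM to 100000 nM.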

Compound 4, half-maximal inhibitory concentration: >= 100000 nM
Compound 4 ended at the assay's limit; the forecaster's own chance of this, stated with the estimate: 10%; at least 1.8-fold (0.25 log units) between middle value and limit.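

In this assay compound 4 gives >= 100000 nM, which is a limit of the assay and not a number. The change from 4-methylphenyl to phenyl on this core can therefore be read only as a floor, an at least 1.9-fold higher number from compound 3 to compound 4 (0.29 log units; that floor lies within the scatter), and this floor shows neither that the change behaves alike on the two cores nor that it behaves differently: the same change on two cores in this assay, a 1.1-fold higher number (0.05 log units; within the scatter) from compound 2 to compound 1 and an at least 1.9-fold higher number (0.29 log units; that floor lies within the scatter) from compound 3 to compound 4; the limit leaves it open whether they differ Whether the small step seen on the first core carries over to the second thus stays undecided, and the true size of the second step is not known: the limit of >= 100000 nM in this assay, at which 1 of the 4 values shown sits.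

The compounds shown leave open what other groups in place of the methyl, such as an amine, a carboxylic acid or a longer chain, would do on either core. How the two cores themselves compare also stays open, as no pair shown separates the parts of the difference between them.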